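The compounds below may be only part of what the source reports. "The series", "measured", "known", "first", "only" and "open" are said of these compounds alone.

For the measured compounds named here, compound 2 `O=C(O)c1csc(-n2nc(-c3ccc(F)cc3)c3ccccc32)n1` is one of two compounds measured in an assay on isolated protein for antagonist activity at prostaglandin E2 receptor EP1 subtype (Homo sapiens), read by reporter gene assay; on this read-out higher numbers stand for weaker inhibition and lower numbers for stronger inhibition. In this assay compound 2 gives 4.5 nM, the lower of the two numbers shown. Compound 1 `O=C(O)c1csc(-n2nc(-c3ccccc3)c3cc(F)ccc32)n1` in this assay gives 80 nM, a higher number that lies beyond the scatter of repeated measurements; the two compounds differ in more than one place, so their values are simply set side by side.

Compound 3 `O=C(O)c1csc(-n2nc(-c3cccc(F)c3)c3ccccc32)n1` has not yet been measured. It differs from compound 2 by 3-fluorophenyl in place of 4-fluorophenyl on an aromatic carbon, a 3-fluorophenyl in place of 4-fluorophenyl on an aromatic carbon. Going by the values given here, no single-change step among the measured compounds shows what such a shift does in this assay; the expectation is therefore a step of small size, if any, most likely toward a somewhat higher number. The step expected from compound 2 to compound 3 is a 2.2-fold higher number from compound 2 to compound 3 (0.35 log units; beyond the scatter). Compound 3 is estimated to give about 10 nM, within a range from 3 nM to 40 nM.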

Compound 3, half-maximal inhibitory concentration: 20 nM
Compound 3: the middle estimate sits 2.0-fold (0.30 log units) below what was measured; low and high end bracket the measured number.
By their numbers in this assay, from the lowest: compound 2; then compound 3; then compound 1.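

In this assay, for the compounds shown here, exchanging 4-fluorophenyl for 3-fluorophenyl gives a 4.4-fold higher number from compound 2 to compound 3 (0.65 log units; beyond the scatter), the first step in this set that can be read as a single change. The two groups have the same atoms, so this modest step, beyond the scatter, shows that the read-out at this aromatic carbon of the five-membered ring responds to where the fluorine sits on the phenyl ring alone. Nothing shown here accounts for why the number rises with this shift.

From the compounds shown here alone, it remains open how a 4-chlorophenyl, a 4-methoxyphenyl or a phenyl without fluorine would compare at this position on the core of compound 2. Also open, going by these compounds, is whether the carboxylic acid on the thiazole could give way to an amide, and how much of the higher number of compound 1 belongs to each of its differences from compound 2.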